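The compounds below may be only part of what the source reports. "The series", "measured", "known", "first", "only" and "open" are said of these compounds alone.

Measured so far:
compound 1 `CC(C)(C)OC(=O)NCCCCCNC(=O)CN1CN(c2ccccc2)C2(CCN(C(=O)c3ccc(C(C)(C)C)cc3)CC2)C1=O` — 13700 nM
compound 2 `CC(C)(C)c1ccc(C(=O)N2CCC3(CC2)C(=O)N(CC(=O)N2CCC(O)CC2)CN3c2ccccc2)cc1` — 4700 nM
compound 3 `COC(=O)CCNC(=O)CN1CN(c2ccccc2)C2(CCN(C(=O)c3ccc(C(C)(C)C)cc3)CC2)C1=O` — "not determined" (no result reported)

In an assay on HEK293 cells for displacement of a labelled ligand from NPC1-like intracellular cholesterol transporter 1 (Homo sapiens) (a lower number here means a stronger inhibitor, a higher number a weaker inhibitor), compound 1 gives 13700 nM and compound 2 gives 4700 nM; both are weak inhibitors. Going by the values given here, compound 3 has no number in this assay, so it stands nowhere on this scale; the only anchors are compound 1 and compound 2, both weak. Compound 4 `CC(C)(C)c1ccc(C(=O)N2CCC3(CC2)C(=O)N(CC(=O)NCN)CN3c2ccccc2)cc1` differs from compound 3 as amino in place of (methoxycarbonyl)methyl on a saturated chain carbon bound to an amide-type nitrogen. Among the compounds with values here, no measured step bears on this change, so no direction beyond the scatter is claimed; the expectation is simply that compound 4 stays in the weak range the two measured values mark out. Compound 4 is accordingly expected to give about 8000 nM in this assay, with a range from 2000 nM to 30000 nM.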

Compound 4, half-maximal inhibitory concentration: 26500 nM
Compound 4: the middle estimate sits 3.3-fold (0.52 log units) below what was measured, and the stated range covers the measured number.
By their numbers in this assay, from the lowest: compound 2; then compounds 1 and 4 (each within the scatter of the next).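

Working notes: with (aminomethyl)amino in place of 4-hydroxypiperidin-1-yl on a carbonyl carbon, this assay shows a 5.6-fold higher number from compound 2 to compound 4 (0.75 log units; beyond the scatter), a modest step beyond the scatter and the first size readable for a change at this carbonyl carbon. With amino in place of 4-((tert-butoxycarbonyl)amino)butyl on a saturated chain carbon bound to an amide-type nitrogen, the reading is a 1.9-fold higher number from compound 1 to compound 4 (0.29 log units; within the scatter), within the scatter, so these two chains cannot be told apart here. No measurement at hand accounts for either step.

Still open, going by these compounds, is how a carboxylic acid in place of (methoxycarbonyl)methyl would read. Also open, on these data alone, is how a plain piperidin-1-yl group on the carbonyl carbon would compare with 4-hydroxypiperidin-1-yl.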